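Swapping a trifluoromethoxy for a trifluoromethyl group

The compounds below may be only part of what the source reports. "The series", "measured", "known", "first", "only" and "open" are said of these compounds alone.

Of the compounds shown here, three have so far been tested in a functional assay on HCT-116 cells (Homo sapiens) for inhibition, read by sulforhodamine B assay, with a stated time of 72 h; on this read-out lower numbers stand for stronger inhibition and higher numbers for weaker inhibition. Compound 1 `CC(c1ccc(-c2ccccc2)c(F)c1)c1nnc2n1N=C(c1ccc(OC(F)(F)F)cc1)CS2` gives 5400 nM, the lowest of the three numbers and therefore the strongest inhibitor in this set. Compound 2 `COc1ccc2cc(C(C)c3nnc4n3N=C(c3ccc(Br)cc3)CS4)ccc2c1` gives 11700 nM in this assay, a number beyond the scatter above that of compound 1. Compound 3 `CC(C)Cc1ccc(C(C)c2n[nH]c(=S)n2N)cc1`, which lacks the full bicyclic part of the shared core, gives 27400 nM in this assay, the highest number of the three.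

The next compound, compound 4 `CC(c1ccc(-c2ccccc2)c(F)c1)c1nnc2n1N=C(c1ccc(C(F)(F)F)cc1)CS2`, keeps everything of compound 1 except one group on the phenyl ring that hangs from the core: trifluoromethyl in place of trifluoromethoxy on an aromatic carbon. Both groups are small, fluorine-rich and uncharged, so in this assay the step is expected to stay within the scatter, with no clear direction. On that basis, the estimate for compound 4 is 5000 nM, with a likely range from 2000 nM to 12500 nM, which is a step of a 1.1-fold lower number from compound 1 to compound 4 (0.03 log units; within the scatter) in this assay.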

Compound 4, half-maximal inhibitory concentration: 6100 nM
Beside the measured number, compound 4's estimate is 1.2-fold (0.09 log units) below it; the range from low to high includes it.
By their numbers in this assay, from the lowest: compounds 1, 4 and 2 (each within the scatter of the next, the first and the last beyond it); then compound 3.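

In this assay, among these compounds, the swap gives a 1.1-fold higher number from compound 1 to compound 4 (0.05 log units; within the scatter), the first comparison in this set in which only one place differs. It shows that, with the rest of the molecule held fixed, trifluoromethyl and trifluoromethoxy on this aromatic carbon cannot be told apart in this read-out, even though the oxygen atom is gone. The data shown offer no explanation for this match.

As far as these compounds go, both groups are fluorine-containing and carry no net charge, so it remains open how this position would respond to a clearly different group, such as an amine or a carboxylic acid. The bromine of compound 2 gives no answer either, as compound 2 also differs from compound 1 elsewhere in the molecule.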